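The source may hold more compounds than are shown below. What is called first, only, known or untested is meant among the compounds shown, and "the series" means these compounds.

- Compound 1 `CC(=O)Oc1ccc2oc(/C=C/[S+](C)[O-])cc(=O)c2c1` gives > 10000 nM as a limit
- Compound 2 `CCCCCOc1ccc2oc(/C=C/[S+](C)[O-])cc(=O)c2c1` gives 6600 nM as a number

Within the data shown here, in a functional assay on DLD-1 cells (Homo sapiens) for cytotoxicity, with a stated time of 48 h (on this read-out higher numbers stand for weaker inhibition and lower numbers for stronger inhibition), compound 2 gives 6600 nM and so holds the only true number so far. Compound 1 gives > 10000 nM as its result, which is a limit of the assay and not a number.

The next compound is compound 3 `CC(C)CC(=O)Oc1ccc2oc(/C=C/[S+](C)[O-])cc(=O)c2c1` with the change isobutylcarbonyl in place of pentyl on an oxygen on an aromatic ring in which isobutylcarbonyl takes the place of pentyl on an oxygen on an aromatic ring. Like the acetyl of compound 1, the new group is attached to that oxygen through a carbonyl.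

Among the measured compounds shown here, one measured step bears on this, namely an at least 1.5-fold lower number from compound 1 to compound 2 (0.18 log units; that floor lies within the scatter) for pentyl in place of acetyl. Its floor lies within the scatter, so it gives no firm size. Going by that step of compound 1 to compound 2, this assay is expected to show no shift beyond the scatter, and any small move would be toward weaker inhibition. The estimated step is a 1.2-fold higher number from compound 2 to compound 3 (0.08 log units; within the scatter) and it stays within the scatter. A limit instead of a number is also possible. For compound 3 the estimate is 8000 nM with an expected range from 3500 nM to 18000 nM in this read-out.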

Compound 3, half-maximal inhibitory concentration: 6100 nM
The estimate for compound 3 lay 1.3-fold (0.12 log units) above the measured number, within the range that was stated.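

In this assay, among these compounds, the change is a 1.1-fold lower number from compound 2 to compound 3 (0.03 log units; within the scatter), the first comparison with a true number at both ends, and it shows that isobutylcarbonyl and pentyl on this oxygen cannot be told apart, so attachment through a carbonyl does not by itself separate compound 3 from compound 2. Within the pair joined through a carbonyl, placing isopropyl in place of hydrogen on a saturated chain carbon bound to a carbonyl carbon gives an at least 1.6-fold lower number from compound 1 to compound 3 (0.21 log units; that floor lies within the scatter), and since that floor lies within the scatter, no firm size can be given for this change. Compound 1 remains a limit and not a number: the limit of > 10000 nM in this assay, at which 1 of the 3 values shown sits.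

Going by these compounds, it remains open whether a longer chain than pentyl, or a chain ending in an amine or a carboxylic acid, would move the number on this oxygen beyond the scatter. The compounds shown also leave open how a free hydroxyl, with only a hydrogen on that oxygen, would compare with these groups.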